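The compounds below may be only part of what the source reports. "The series", "measured", "known", "first", "only" and "open" are said of these compounds alone.

Of the compounds shown here, two have so far been measured in a functional assay on Huh-7 cells (Homo sapiens) for inhibition, read by MTT assay, with a stated time of 48 h; a higher number here means a weaker inhibitor, a lower number a stronger inhibitor. Compound 1, `COc1ccc2c(=O)c(/C=C/C(=O)Nc3ccc(Cl)cc3)coc2c1`, gives 37100 nM in this assay, the higher of the two numbers. Going by the values given here, compound 2, `O=C(/C=C/c1coc2cc(O)ccc2c1=O)Nc1ccccc1`, gives 3880 nM in this assay, a lower number than that of compound 1 by a gap beyond the scatter; since the two structures differ in more than one place, no single step between them can be traced. The untested compound 3, `COc1cccc(NC(=O)/C=C/c2coc3cc(OC)ccc3c2=O)c1`, departs from compound 1 by one change: 3-methoxyphenyl in place of 4-chlorophenyl on an amide-type nitrogen. A 3-methoxyphenyl thus replaces a 4-chlorophenyl on the amide-type nitrogen whose other neighbour is a carbonyl carbon. Among the compounds with values here, no measured pair shows what this exchange alone does to the number. A modest step is expected, a 1.7-fold lower number from compound 1 to compound 3 (0.23 log units; within the scatter), most likely within the scatter and if anything toward a lower number. Compound 3 is estimated at 22000 nM in this assay, with a range from 7000 nM to 70000 nM.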

Compound 3, half-maximal inhibitory concentration: 11100 nM
Compound 3: middle estimate off by 2.0-fold (0.30 log units), on the high side, and the stated range covers the measured number.
By their numbers in this assay, from the lowest: compound 2; then compound 3; then compound 1.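

Going by these compounds alone, on the amide-type nitrogen whose other neighbour is a carbonyl carbon, the group attached can shift the number in this assay while the shared core stays the same: 3-methoxyphenyl in place of 4-chlorophenyl gives a 3.3-fold lower number from compound 1 to compound 3 (0.52 log units; beyond the scatter) and so provides the first single change that can be traced here. This one exchange alters several things together, since chlorine leaves, oxygen enters, the count of hydrogen-bond acceptors on the group goes from 0 to 1, and the ring position named for the substituent also differs. No measurement here explains why the number falls.

Which of these differences matters remains open, and a 3-chlorophenyl or a 4-methoxyphenyl on the same nitrogen would help to separate them. As far as these compounds go, how an amine or a carboxylic acid on that ring would read also remains unknown.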